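Side chain extension: compound 2 to compound 4

This account rests on a few compounds, and the source may have more. Where it says the series, first, only, none or still open, it means among the compounds named here.

In a functional assay on NCI-H358 cells (Homo sapiens) for cytotoxicity, read by sulforhodamine B assay (a higher number here means that more compound is needed for the effect, a lower number that less compound is needed), compound 2 (`CCCCCCCCCCCCCC[C@@H](O)[C@@H](O)[C@H](CO)n1cc(CCCC)nn1`) stands at 12900 nM and compound 1 (`CCCCCCCCCCCCCC[C@@H](O)[C@@H](O)[C@H](CO)n1cc(CCC)nn1`) at 13200 nM with the two numbers within the scatter of each other. For the measured compounds named here, these are the only two numeric values so far. Compound 3 (`CCCCCCCCCCCCC/C=C/[C@@H](O)[C@H](CO)n1cc(CCCCCCCCCCCCC)nn1`) gives > 50000 nM and this is a limit of the assay, not a number.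

The change to compound 4 (`CCCCCCCCCCCCCC[C@@H](O)[C@@H](O)[C@H](CO)n1cc(CCCCCCCCCCCCC)nn1`) is large: nonyl in place of hydrogen on a saturated chain carbon, four bonds along the chain from an aromatic carbon on the side chain of compound 2. Going by the values given here, the one measured step, a single methyl in place of hydrogen, is a 1.0-fold lower number from compound 1 to compound 2 (0.01 log units; within the scatter) and so gives no direction for a change of this size. Among the compounds with values here, compound 3 is the one measured compound with a long chain at this place, and a step to a higher number in this assay is expected because of the limit of > 50000 nM in this assay, at which 1 of the 3 values shown sits, in that compound. The expected step is a 2.7-fold higher number from compound 2 to compound 4 (0.43 log units; beyond the scatter) as an estimate only. For compound 4 the estimated value is 35000 nM in a range from 14000 nM to 90000 nM and the assay may report only a limit.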

Compound 4, half-maximal effective concentration: > 50000 nM
Compound 4 gave a limit, no number; the forecaster's own chance of this, stated with the estimate: 50%; at least 1.4-fold (0.15 log units) between middle value and limit.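

For the compounds shown here, at this place chain length now registers in this assay: nonyl in place of hydrogen gives an at least 3.8-fold higher number from compound 2 to compound 4 (0.58 log units; beyond the scatter), whereas the single methyl step among the short chains stayed within the scatter. Counted from the shorter chain, decyl in place of hydrogen gives an at least 3.7-fold higher number from compound 1 to compound 4 (0.57 log units; beyond the scatter), so compound 4 stands apart from both short-chain compounds. The reading for compound 4 is a limit of the assay and not a number, so both steps give only a minimum size, and limits now make up a large share of the series: the limit of > 50000 nM in this assay, at which 2 of the 4 values shown sit.

Open, on these data alone, is where along the chain the numbers begin to climb, a gap that a hexyl or octyl chain at this place would fall into. Also open, as far as these compounds go, is whether a side chain ending in an amine or a carboxylic acid would keep the numbers of compound 1 and compound 2 or shift them.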